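The source may hold more compounds than are shown below. What is called first, only, known or untested is meant among the compounds shown, and "the series" means these compounds.

Measured compounds in this series:
- compound 1 `Cc1cc(-c2ccc(F)nc2F)nn(Cc2ccc(Cl)cc2)c1=O`: 83800 nM
- compound 2 `O=c1c(CO)cc(-c2ccc(F)nc2F)nn1Cc1ccc(Cl)cc1`: > 100000 nM
- compound 3 `Cc1ccc(-c2nn(Cc3ccc(C#N)cc3)c(=O)c3ccccc23)c(F)n1`: > 100000 nM

For the measured compounds named here, in an ADME assay on HepG2 2.2.15 cells (Homo sapiens) for cytotoxicity, read by MTT assay, with a stated time of 8 days (a lower number here means that less compound is tolerated, a higher number that more compound is tolerated), compound 1 gives 83800 nM and is the only compound of the three with a numerical value. Compound 2 reaches only a limit of the assay, > 100000 nM. Compound 3 likewise stands at a limit of the assay, > 100000 nM, so no number is known for it, only that it sits at the ceiling. The picture is summed up by the limit of > 100000 nM in this assay, at which 2 of the 3 values shown sit.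

Going by the values given here, the single measured step, an at least 1.1-fold higher number from compound 1 to compound 2 (0.07 log units; that floor lies within the scatter), lies within the scatter and ends at the limit. It concerns the hydroxy-for-hydrogen change and not the change now considered, so it bears on the present step only in showing that a small substituent exchange on the shared core moved the number no further than the scatter.

Compound 4 `CCOc1ccc(-c2nn(Cc3ccc(C#N)cc3)c(=O)c3ccccc23)c(F)n1` differs from compound 3 as follows: ethoxy in place of methyl on an aromatic carbon. Among the compounds with values here, no measured step of this kind exists, and nothing in the data points to a movement beyond the scatter. Compound 4 is therefore expected to remain at the limit of this assay, with the expected step of a number no higher from compound 3 to compound 4 (the limit leaves the size open). The estimate for compound 4 is 100000 nM, between 60000 nM and 200000 nM.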

Compound 4, half-maximal cytotoxic concentration: > 100000 nM
Compound 4: no number, only a limit; the forecaster's own chance of this, stated with the estimate: 75%; the middle value lies on the limit itself.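

In this assay compound 3 and compound 4 both stand at a limit, so no step can be read between them: the limit of > 100000 nM in this assay, at which 3 of the 4 values shown sit. Still open, as far as these compounds go, is how far beyond that limit compound 3 and compound 4 lie, and whether ethoxy in place of methyl on an aromatic carbon moves the number at all.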